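The compounds below may be only part of what the source reports. "The series", "measured", "known", "first", "only" and "open" are said of these compounds alone.

In a functional assay on PANC-1 cells (Homo sapiens) for inhibition, read by MTT assay, with a stated time of 24 h (a lower number here means a stronger inhibitor, a higher number a weaker inhibitor), two compounds built on a shared core have been measured so far. Compound 1 `CC1(C)[C@H]2CC[C@]1(C)N(Cc1cn(-c3cccc(F)c3)nn1)C(=O)C2`, which carries a 3-fluorophenyl group, gives 220 nM. Compound 2 `CC1(C)[C@H]2CC[C@]1(C)N(Cc1cn(-c3ccc(O)cc3)nn1)C(=O)C2`, which carries a 4-hydroxyphenyl group, gives 100 nM, the lower of the two numbers. The next compound is compound 3 `CC1(C)[C@H]2CC[C@]1(C)N(Cc1cn(-c3ccccc3O)nn1)C(=O)C2`, with 2-hydroxyphenyl in place of 4-hydroxyphenyl on an aromatic nitrogen. For the measured compounds named here, only one measured step bears on this change, a 2.2-fold lower number from compound 1 to compound 2 (0.34 log units; beyond the scatter). That modest step swapped a fluorine-bearing ring for a hydroxyl-bearing one, so it says little about shifting the hydroxyl alone. Going by the values given here, no measured compound carries the 2-hydroxyphenyl group, so a step of similar modest size towards a higher number is expected, with real doubt about its direction. The estimated change is a 2.2-fold higher number from compound 2 to compound 3 (0.34 log units; beyond the scatter). For compound 3 the expected value is 220 nM, with an estimated range of 70 nM to 700 nM.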

Compound 3, half-maximal inhibitory concentration: 230 nM
For compound 3 the middle estimate is 1.0-fold (0.02 log units) below the measured one, within the range that was stated.
By their numbers in this assay, from the lowest: compound 2; then compounds 1 and 3 (each within the scatter of the next).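

Moving the hydroxyl on an otherwise unchanged ring matters in this assay: 2-hydroxyphenyl in place of 4-hydroxyphenyl gives a 2.3-fold higher number from compound 2 to compound 3 (0.36 log units; beyond the scatter), a modest step between two groups with the same atoms. A hydroxyl on this ring is therefore not enough to give the lower number, as the 3-fluorophenyl and 2-hydroxyphenyl compounds show a 1.0-fold higher number from compound 1 to compound 3 (0.02 log units; within the scatter), so where the group stands counts as well as what it is. No measurement shown here explains this difference.

From the compounds shown here alone, how much of the lower number of compound 2 comes from the hydroxyl itself remains open. An amine or a methoxy group in place of the hydroxyl, or a plain phenyl ring, would help separate the effect of the group from the effect of its place.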